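Adding a Second Bromine to an Amide at the Limit

The source may report more compounds than this note shows. Statements on the series, on what has been measured and on what is new or still open speak of the compounds shown alone.

Compound 1, `O=C(Nc1ccc(Sc2nc3ccccc3s2)c(Cl)c1)c1cccc(Br)c1O`, was tested in an assay on isolated protein for inhibition of thiosulfate sulfurtransferase (Homo sapiens), with a stated time of 60 min, in the absence of a further agent; a lower number here means a stronger inhibitor, a higher number a weaker inhibitor. In this assay compound 1 gives only > 100000 nM, which is a limit of the assay and not a number. Compound 3, `O=C(Nc1ccc(Sc2nc3ccccc3s2)cc1)c1cccc(Br)c1O`, gives > 100000 nM, again a limit. Compound 2, `O=C(Nc1cccc(Cl)c1)c1cc(Br)cc(Br)c1O`, likewise gives > 100000 nM, also a limit. The only measured step among these, a step that the two limits leave unreadable from compound 1 to compound 3, has no readable size; all three values sit at the same edge (the limit of > 100000 nM in this assay, at which 3 of the 3 values shown sit).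

The change to compound 4, `O=C(Nc1ccc(Sc2nc3ccccc3s2)c(Cl)c1)c1cc(Br)cc(Br)c1O`, is bromo in place of hydrogen on an aromatic carbon; one bond further out it reads as 3-bromo-2-hydroxyphenyl to 3,5-dibromo-2-hydroxyphenyl. For the measured compounds named here, no measured step shows how this change acts here. Compound 2 also carries the 3,5-dibromo-2-hydroxyphenyl part and sits at the limit. Compound 4 is therefore expected to give 150000 nM, with a range from 30000 nM to 1000000 nM, and most likely the assay will again report only a limit. The expected step that the limit leaves unreadable from compound 1 to compound 4 is estimated to stay within the scatter.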

Compound 4, half-maximal inhibitory concentration: > 100000 nM
Compound 4: a limit, no number; the forecaster's own chance of this, stated with the estimate: 85%; the middle value lies beyond the limit too.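

For the compounds shown here, compound 1 and compound 4 each give only a limit of the assay and not a number, and no step between them can be read: the limit of > 100000 nM in this assay, at which 4 of the 4 values shown sit. The compounds shown leave open whether the added bromo, or any other change among them, alters inhibition at all.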